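The source may hold more compounds than are shown below. What is called first, only, known or untested is meant among the compounds shown, and "the series" means these compounds.

Compound 1 `C/C=C(\C)C(=O)O[C@H]1[C@]2(C)C[C@@H]3O[C@@]1(O)C=C1C4=CC(=O)O[C@@H](c5ccoc5)[C@]4(C)CC[C@@H]1[C@]3(C)[C@@H]2[C@@H](O)C(=O)OC`: > 100000 nM, a limit of the assay
Compound 2 `COC(=O)[C@H](O)[C@@H]1[C@@]2(C)C[C@@H]3O[C@@](O)(C=C4C5=CC(=O)O[C@@H](c6ccoc6)[C@]5(C)CC[C@@H]4[C@@]31C)[C@H]2O`: > 100000 nM, a limit of the assay
Compound 3 `C/C=C(\C)C(=O)O[C@H]1[C@]2(C)C[C@@H]3O[C@@]1(O)C=C1C4=CC(=O)O[C@@H](c5ccoc5)[C@]4(C)CC[C@@H]1[C@]3(C)[C@@H]2C(=O)C(=O)OC`: > 100000 nM, a limit of the assay

In a functional assay on SK-OV-3 cells (Homo sapiens) for inhibition, read by MTT assay, with a stated time of 24 h (on this read-out higher numbers stand for weaker inhibition and lower numbers for stronger inhibition), compound 1 gives only a limit, > 100000 nM, and no number. Compound 2 likewise gives only a limit in this assay, > 100000 nM. Compound 3 too stops at a limit in this assay, > 100000 nM. The two single-point steps that start from compound 1 therefore cannot be sized: a step that the two limits leave unreadable from compound 1 to compound 2 and a step that the two limits leave unreadable from compound 1 to compound 3. All that the numbers show is the limit of > 100000 nM in this assay, at which 3 of the 3 values shown sit, so compound 1 stands at the limit together with every other measured compound, and no measured step can be read in either direction.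

Compound 4 `C/C=C(\C)C(=O)O[C@@H]1[C@]2(OC(=O)CCCC)C=C3C4=CC(=O)O[C@@H](c5ccoc5)[C@]4(C)CC[C@@H]3[C@@]3(C)[C@H](C[C@]1(C)[C@H]3[C@@H](O)C(=O)OC)O2` is the untested partner of compound 1. The change is butylcarbonyl in place of hydrogen on an oxygen on a saturated carbon. The step from compound 1 to compound 2 also concerns an acyl group on an oxygen on a saturated carbon, but its size is not readable, and nothing else bears on this change. With three limits and no readable step, the expectation for compound 4 in this assay is a step of about a number no higher from compound 1 to compound 4 (the limit leaves the size open) from compound 1, meaning no readable move. Compound 4 is thus estimated at 100000 nM, within 30000 nM to 300000 nM, and most likely again only a limit.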

Compound 4, half-maximal inhibitory concentration: 13700 nM
Beside the measured number, compound 4's estimate is 7.3-fold (0.86 log units) above it, outside the stated range (below it).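

In this assay, among these compounds, setting butylcarbonyl in place of hydrogen on this oxygen gives the first step that can be read, an at least 7.2-fold lower number from compound 1 to compound 4 (0.86 log units; beyond the scatter), whereas the earlier steps from compound 1 could not be sized. This shows that the read-out can move with a change at this hydroxy group, and the step is only a minimum, as its starting point, compound 1, is a limit and not a number. Compound 4 is the only compound shown that carries a number rather than a limit: the limit of > 100000 nM in this assay, at which 3 of the 4 values shown sit.

The compounds shown leave open whether this move belongs to butylcarbonyl in particular or would also come with a shorter acetyl group, a longer octanoyl chain or a benzoyl group on the same oxygen. They also leave open whether an ether or a carbamate at this place would do the same, and whether butylcarbonyl would move the read-out in the same way on the core of compound 2 or compound 3.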